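Working notes on the series: from compound 3 to compound 4

The compounds below may be only part of what the source reports. "The series", "measured", "known", "first", "only" and "open" are said of these compounds alone.

Measured so far, in a functional assay on A2780 cells (Homo sapiens) for inhibition, read by MTT assay, with a stated time of 72 h; a higher number here means a weaker inhibitor of growth, a lower number a stronger inhibitor of growth:
- compound 1, `N#C/C(=C\c1c(F)c(F)c(F)c(F)c1F)C(=O)c1ccc[nH]1`: 64000 nM
- compound 2, `N#C/C(=C\c1ccc([N+](=O)[O-])cc1)C(=O)c1c[nH]c2ccccc12`: 48000 nM
- compound 3, `COc1ccc(CNC(=O)/C(C#N)=C/c2ccc[nH]2)cc1`: > 50000 nM

Compound 1 and compound 2 both give numbers in this assay, and both sit in the weak range. For compound 3 this assay reports only a limit, > 50000 nM. Nothing in this set is a strong inhibitor of growth, and compound 3, sitting at that limit (the limit of > 50000 nM in this assay, at which 1 of the 3 values shown sits), cannot be ranked against compound 1 or compound 2 on the numbers shown.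

The next compound, compound 4, is `COc1ccc(CNC(=O)/C(C#N)=C/c2cc(Br)co2)cc1`. It differs from compound 3 in one place: 4-bromofuran-2-yl in place of 1H-pyrrol-2-yl on a double-bonded chain carbon bound to a double-bonded chain carbon. Among the measured compounds shown here, no pair of measured compounds with a single difference is available, so the size of this step can only be guessed. Compound 3 sits at the limit, and nothing in the series argues for a large gain from this exchange. The step from compound 3 to compound 4 is expected to be small, a step that the limit leaves unreadable from compound 3 to compound 4, with compound 4 likely to remain weak and quite possibly to report a limit again. For compound 4 the expected value in this assay is 60000 nM, in a range from 15000 nM to 200000 nM.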

Compound 4, concentration for 50% growth inhibition: 28000 nM
Estimate against measurement, compound 4: 2.1-fold (0.33 log units) above; the range from low to high includes it.
By their numbers in this assay, from the lowest: compounds 4, 2 and 1 (each within the scatter of the next, the first and the last beyond it).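

In this assay, compound 4 returns a number where compound 3 returns only a limit, which gives the first readable result at this place on a double-bonded chain carbon bound to a double-bonded chain carbon. Among the compounds shown here, the single exchange of 1H-pyrrol-2-yl for 4-bromofuran-2-yl gives an at least 1.7-fold lower number from compound 3 to compound 4 (0.25 log units; that floor lies within the scatter), so only a minimum size is known: the true step may be larger, but the minimum alone does not show a real change. The value for compound 3 remains a limit and not a number: the limit of > 50000 nM in this assay, at which 1 of the 4 values shown sits.

The exchange alters several things at once, as the ring nitrogen with its hydrogen-bond donor leaves while the ring oxygen and the bromine enter, and the compounds shown do not separate these contributions. A plain furan-2-yl group would isolate the ring change, and chlorine or a methyl group in place of the bromine would test whether the bromine itself matters to the growth inhibition seen with compound 4.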